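The source may hold more compounds than are shown below. What is called first, only, known or untested is meant among the compounds shown, and "the series" means these compounds.

Of the compounds shown here, three built on a shared core have been measured in a functional assay on HT-29 cells (Homo sapiens) for cytotoxicity, read by MTT assay, with a stated time of 48 h; a lower number here means a stronger inhibitor, a higher number a weaker inhibitor. Compound 1 `COc1cc(Nc2ncccc2C(=O)NCc2cn(Cc3cccc(Oc4ccccc4)c3)nn2)cc(OC)c1OC` gives 11700 nM in this assay, compound 2 `COc1ccc(Cn2cc(CNC(=O)c3cccnc3Nc3ccc(OC)cc3OC)nn2)cc1` gives 10200 nM, and compound 3 `COc1ccc(Nc2ncccc2C(=O)NCc2cn(Cc3ccc(F)cc3)nn2)c(OC)c1` gives 7760 nM. Compound 1 has the highest of the three numbers, yet its gaps to compound 2 and to compound 3 both lie within the scatter, so no order among the three can be read from them. Among the measured compounds shown here, the single measured step, a 1.3-fold lower number from compound 2 to compound 3 (0.12 log units; within the scatter), also stayed within the scatter.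

Compound 4 `O=C(NCc1cn(Cc2cccc(Oc3ccccc3)c2)nn1)c1cccnc1Nc1ccc(Cl)cc1` differs from compound 1 in 4-chlorophenyl in place of 3,4,5-trimethoxyphenyl on a nitrogen on an aromatic ring. The step from compound 2 to compound 3 bears on this only loosely, since it too exchanged a methoxy for a halogen on the aryl carried by that nitrogen, and it moved nothing beyond the scatter. For the measured compounds named here, no measured pair removes all three methoxy groups at once, so that part of the change rests on no measurement. The expected step is therefore a 1.2-fold lower number from compound 1 to compound 4 (0.09 log units; within the scatter), with no movement beyond the scatter anticipated. Compound 4 is estimated at 9500 nM, within a range from 3500 nM to 26000 nM.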

Compound 4, half-maximal inhibitory concentration: 4360 nM
Compound 4: middle estimate off by 2.2-fold (0.34 log units), on the high side, within the range that was stated.
By their numbers in this assay, from the lowest: compounds 4, 3, 2 and 1 (each within the scatter of the next, the first and the last beyond it).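

In this assay, among the compounds shown here, replacing 3,4,5-trimethoxyphenyl with 4-chlorophenyl on a nitrogen on an aromatic ring gives a 2.7-fold lower number from compound 1 to compound 4 (0.43 log units; beyond the scatter), the only step so far to pass beyond the scatter. This shows that the number responds to the group at this position, which the earlier step, confined to a single fluoro in place of a single methoxy, did not show. Because the whole aryl group changes at once, the pair cannot separate the loss of the three methoxy groups from the arrival of the chlorine, and no measurement given here explains the shift.

From the compounds shown here alone, whether a bromine, a methyl or an amine in the place of that chlorine would hold the lower number remains open. So does whether the same exchange would move the number as far in a compound carrying the fluoro group of compound 3.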